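Removing a Methoxy Group: Expected Effect on Maximal Response

The source may report more compounds than this note shows. Statements on the series, on what has been measured and on what is new or still open speak of the compounds shown alone.

Compound 1 `CC(=O)OCC(C)(C)NC(=O)N(CCC1CCN(Cc2ccc(C)cc2)CC1)Cc1ccc(-c2ccc(F)cc2)cc1`: 92.3%
Compound 2 `COc1ccc(-c2ccc(CN(CCC3CCN(Cc4ccc(C)cc4)CC3)C(=O)NC(C)(C)COC(C)=O)cc2)cc1`: 112%

Both were tested in an in vitro functional assay on HEK293 cells for antagonist activity at melanin-concentrating hormone receptor 1 (Homo sapiens); on this read-out higher numbers stand for larger maximal responses and lower numbers for smaller maximal responses. Going by the values given here, compound 2 has the higher of the two numbers, and the only step known so far is a number 19.7 percentage points higher from compound 1 to compound 2 (beyond the scatter), a modest one. Compound 3 `CC(=O)OCC(C)(C)NC(=O)N(CCC1CCN(Cc2ccc(C)cc2)CC1)Cc1ccc(-c2ccccc2)cc1` differs from compound 2 by hydrogen in place of methoxy on an aromatic carbon. Since that one step raised the response when methoxy replaced fluoro, taking the methoxy away is expected to bring the number back toward that of compound 1, a step of a number 15 percentage points lower from compound 2 to compound 3 (beyond the scatter) in this assay . Compound 3 is therefore estimated at 97%, expected between 80% and 114%.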

Compound 3, largest response reached (reported as Imax), in percent of the reference or control that the assay uses: 102%
Compound 3: the middle estimate sits 5 percentage points below what was measured; the measured number falls inside the stated range.
By their numbers in this assay, from the lowest: compounds 1, 3 and 2 (each within the scatter of the next, the first and the last beyond it).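

In this assay, hydrogen in place of methoxy is a number 10 percentage points lower from compound 2 to compound 3 (within the scatter), and hydrogen in place of fluoro is a number 9.7 percentage points higher from compound 1 to compound 3 (within the scatter). At this position, then, the plain phenyl cannot be told apart from either substituted compound, and only the fluoro and methoxy compounds sit beyond the scatter from each other. Nothing available explains these numbers.

On these data alone, whether an amine or a carboxylic acid in this same place would separate clearly from hydrogen stays open. So does whether an ethoxy group would follow methoxy.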